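The source may report more compounds than this note shows. Statements on the series, on what has been measured and on what is new or still open speak of the compounds shown alone.

Measured so far: compound 1 `CCC(C)(C)Cc1c[nH]c(CCc2ccc(-c3cccc(N)n3)cc2)n1` and compound 2 `CCC(C)(C)Cc1c[nH]c(CCc2ccc(-c3cccnc3)cc2)n1`.

In a functional assay on HEK293 cells for agonist activity at Bombesin receptor subtype-3 (Mus musculus), read by luminescence and calcium flux, with a stated time of 10 min (a lower number here means that less compound is needed, a higher number that more compound is needed for the effect), compound 1 gives 119 nM. Among the measured compounds shown here, compound 2 gives 97 nM in this assay, and the two values lie within the scatter of each other; the one measured step, a 1.2-fold lower number from compound 1 to compound 2 (0.09 log units; within the scatter), exchanged the whole ring that hangs from the shared core.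

For the measured compounds named here, compound 3 `CCC(C)(C)Cc1c[nH]c(CCc2ccc(-c3cccc(C#N)n3)cc2)n1` keeps that ring and changes only one group on it: cyano in place of amino on an aromatic carbon. Going by the values given here, no measured step here alters this group alone, so there is nothing to set a direction. Compound 3 is expected to give about 150 nM, within 50 nM to 450 nM, so the expected step is a 1.3-fold higher number from compound 1 to compound 3 (0.10 log units; within the scatter).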

Compound 3, half-maximal effective concentration: 115 nM
For compound 3 the middle estimate is 1.3-fold (0.12 log units) above the measured one; low and high end bracket the measured number.
By their numbers in this assay, from the lowest: compounds 2, 3 and 1 (each within the scatter of the next).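

Cyano in place of amino on this aromatic carbon, next to the ring nitrogen, gives a 1.0-fold lower number from compound 1 to compound 3 (0.01 log units; within the scatter) in this assay, so the hydrogen-bond donor of the amino group can be lost here without a step beyond the scatter. The other new step, a 1.2-fold higher number from compound 2 to compound 3 (0.07 log units; within the scatter), links the nitrile to the unsubstituted pyridin-3-yl compound and likewise stays inside that scatter. No evidence is available to explain these results.

On these data alone, whether a carboxylic acid or a longer chain at this position would move the number beyond the scatter stays open. So does the effect of a methoxy group here.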